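Replacing the Pyrazole on the Shared Core of Compound 1

The compounds below may be only part of what the source reports. "The series", "measured", "known", "first", "only" and "open" are said of these compounds alone.

Measured compounds:
compound 1 `Cn1cc(-c2cc(C(O)(C(F)(F)F)C(F)(F)F)cnc2N2CCN(S(=O)(=O)c3ccc(N)nc3)CC2)cn1` gives 19 mL.min-1.g-1 in an ADME assay (liver) for metabolic stability, with Liver microsome (Homo sapiens) as the target, using microsomes and NADPH, with a stated time of 30 min, tested at 1 uM; on this read-out lower numbers stand for slow clearance and higher numbers for fast clearance.
compound 2 `CS(=O)(=O)c1ccc(-c2cc(C(O)(C(F)(F)F)C(F)(F)F)cnc2N2CCN(S(=O)(=O)c3ccc(N)nc3)CC2)cc1` gives 32 mL.min-1.g-1 in this assay.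
compound 3 `Cc1nc2cc(-c3cc(C(O)(C(F)(F)F)C(F)(F)F)cnc3N3CCN(S(=O)(=O)c4ccc(N)nc4)CC3)ccc2o1` reaches only a limit of the assay in this assay, < 14 mL.min-1.g-1.

Compound 1 and compound 2 lie within the scatter of each other, as a 1.7-fold higher number from compound 1 to compound 2 (0.23 log units; within the scatter) shows. For compound 3 the value is a limit, (the limit of < 14 mL.min-1.g-1 in this assay, at which 1 of the 3 values shown sits), so its distance from compound 1 is known only as an at least 1.3-fold lower number from compound 1 to compound 3 (0.13 log units; that floor lies within the scatter), while the gap from compound 2 is an at least 2.2-fold lower number from compound 2 to compound 3 (0.35 log units; beyond the scatter).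

Compound 4 `Nc1ccc(S(=O)(=O)N2CCN(c3ncc(C(O)(C(F)(F)F)C(F)(F)F)cc3-c3ccc4c(c3)CC(=O)N4)CC2)cn1` has not yet been measured in this assay. It differs from compound 1 in one place: a group of 10 heavy atoms (8 carbon, 1 nitrogen, 1 oxygen; one five-membered non-aromatic ring with 1 hetero atom, one six-membered aromatic ring of carbon only) in place of a group of 6 heavy atoms (4 carbon, 2 nitrogen; one five-membered aromatic ring with 2 hetero atoms), on an aromatic carbon.

The two measured steps that start from compound 1 replace the same 1-methyl-1H-pyrazol-4-yl group, and neither moves the number beyond the scatter in a clear way; only the comparison of compound 2 with compound 3 is a modest change. Among the measured compounds shown here, the group entering in compound 4 resembles the one entering in compound 3 in carrying a second ring, so no large step is expected. Compound 4 is expected to give about 16 mL.min-1.g-1, within a range of 8 mL.min-1.g-1 to 32 mL.min-1.g-1. The estimated step is a 1.2-fold lower number from compound 1 to compound 4 (0.07 log units; within the scatter), which would stay within the scatter.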

Compound 4, intrinsic clearance in microsomes: < 14 mL.min-1.g-1
Compound 4 gave a limit, no number (the forecaster's own chance of this, stated with the estimate: 30%); middle value at least 1.1-fold (0.05 log units) away from the limit.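

In this assay, compound 4 sits at a limit of the assay rather than at a number, as compound 3 does: the limit of < 14 mL.min-1.g-1 in this assay, at which 2 of the 4 values shown sit. Against the 1-methyl-1H-pyrazol-4-yl group, the change reads as an at least 1.3-fold lower number from compound 1 to compound 4 (0.13 log units; that floor lies within the scatter), so no order can be claimed for that pair, whereas against the 4-(methylsulfonyl)phenyl group it reads as an at least 2.2-fold lower number from compound 2 to compound 4 (0.35 log units; beyond the scatter). Compound 3 alone could not show that this position, on an aromatic carbon two atoms from the ring nitrogen, gives the same outcome with a second two-ring group, here one whose five-membered ring is non-aromatic and which carries a hydrogen-bond donor, though compound 1 is not clearly separated from either two-ring compound.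

No step can be read between compound 3 and compound 4, since both values are limits, so their true clearances could be alike or far apart. Going by these compounds, it also remains open whether the second ring matters at all, which a plain phenyl ring or a small amine such as morpholine at this position would help to test.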